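The compounds below may be only part of what the source reports. "The series", "measured", "known", "first", "only" and "open" are said of these compounds alone.

Measured compounds:
- compound 1, `CCOc1ccc(Cl)cc1-c1cc2nc(N)nc(N)c2cc1C`: 11.1 nM
- compound 2, `CCc1ccccc1-c1cc2nc(N)nc(N)c2cc1C`: 41.1 nM
- compound 3, `CC(=O)c1cccc(-c2ccc3c(N)nc(N)nc3c2)c1`: 323 nM

Of the compounds shown here, three that share a core have been tested in an assay on isolated protein for inhibition of Dihydrofolate reductase (Homo sapiens), read by spectrophotometry, using NADPH, with a stated time of 10 min; a higher number here means a weaker inhibitor, a lower number a stronger inhibitor. Compound 1 gives 11.1 nM, the lowest number of the three. Compound 2 gives 41.1 nM, a higher number, and the gap between compound 1 and compound 2 is beyond the usual scatter. Compound 3 gives 323 nM, the highest number, again beyond the scatter when set against compound 1. Compound 1 is therefore the strongest inhibitor of the three in this assay.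

The step under consideration leads from compound 1 to compound 4, `CCOc1ccc(C=O)cc1-c1cc2nc(N)nc(N)c2cc1C`. The change is formyl in place of chloro on an aromatic carbon. For the measured compounds named here, no pair of measured compounds shows this change, so its effect in this assay is not known from what has been measured. A step of modest size is expected, more likely toward a higher number than a lower one, and possibly no further than the scatter; the estimated step is a 1.8-fold higher number from compound 1 to compound 4 (0.26 log units; within the scatter). Compound 4 is estimated to give 20 nM, with a range from 6 nM to 70 nM.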

Compound 4, inhibition constant: 12 nM
Estimate against measurement, compound 4: 1.7-fold (0.22 log units) above; the measured number falls inside the stated range.
By their numbers in this assay, from the lowest: compounds 1 and 4 (each within the scatter of the next); then compound 2; then compound 3.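

In this assay the step is a 1.1-fold higher number from compound 1 to compound 4 (0.03 log units; within the scatter) for formyl in place of chloro on an aromatic carbon para to an ethoxy group. The earlier compounds shown here offered no pair differing in one place, and this pair shows that at this position the two groups cannot be told apart in this assay, although formyl brings one more heavy atom and a hydrogen-bond acceptor that chloro does not. No measurement shown here explains why the two groups read alike.

From the compounds shown here alone, whether an amine, a carboxylic acid or a longer chain on this same carbon would also read alike remains open. A single pair also cannot tell whether formyl in place of chloro would give a similar step on another compound of this series.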